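A few compounds are considered here, and "the series" means these few. Any claim that something is new, unique, unknown or untested is made for them only; others in the source may bear on it.

Of the compounds shown here, three that share one core have been measured in an assay on LM cells for displacement of a labelled ligand from Neuropeptide Y receptor type 5 (Homo sapiens); on this read-out lower numbers stand for stronger inhibition and higher numbers for weaker inhibition. Compound 1 `Fc1ccc(C2(c3ccc(F)cc3)CNC(c3cccc(Br)c3)=N2)cc1` gives 4.8 nM, compound 2 `O=[N+]([O-])c1cccc(C2=NC(c3ccc(F)cc3)(c3ccc(F)cc3)CN2)c1` gives 4.3 nM, and compound 3 `Nc1cccc(C2=NC(c3ccc(F)cc3)(c3ccc(F)cc3)CN2)c1` gives 300 nM. Compound 2 has the lowest number of the three; its nearest neighbour is compound 1, with a 1.1-fold lower number from compound 1 to compound 2 (0.05 log units; within the scatter), and its furthest is compound 3, with a 70-fold higher number from compound 2 to compound 3 (1.84 log units; beyond the scatter). Compound 3 also stands far from compound 1, with a 63-fold higher number from compound 1 to compound 3 (1.80 log units; beyond the scatter).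

Compound 4 `Fc1ccc(C2(c3ccc(F)cc3)CNC(c3cccnc3)=N2)cc1` has not yet been measured. It differs from compound 2 in one place: pyridin-3-yl in place of 3-nitrophenyl on a carbon with a double bond to nitrogen. Within the data shown here, none of the measured steps makes this exact change. Swapping bromo for nitro left the number within the scatter, whereas swapping either of them for amino brought a large rise. Replacing the whole 3-nitrophenyl by pyridin-3-yl, a ring with one hetero atom in place of a ring of carbon only, is a third kind of change that the measured steps do not cover, so a moderate rise in the number is expected rather than none, with the estimate for compound 4 in this assay being 30 nM, within 8 nM to 150 nM. That estimate means an expected step of a 7.0-fold higher number from compound 2 to compound 4 (0.84 log units; beyond the scatter).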

Compound 4, half-maximal inhibitory concentration: 7.2 nM
Beside the measured number, compound 4's estimate is 4.2-fold (0.62 log units) above it; the measured number lies below the stated range.
By their numbers in this assay, from the lowest: compounds 2, 1 and 4 (each within the scatter of the next); then compound 3.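

In this assay, this place on the carbon with a double bond to nitrogen accepts a change of the whole ring, not only of the group on it: replacing 3-nitrophenyl with pyridin-3-yl gives a 1.7-fold higher number from compound 2 to compound 4 (0.22 log units; within the scatter), and replacing 3-bromophenyl with the same ring gives a 1.5-fold higher number from compound 1 to compound 4 (0.18 log units; within the scatter). The earlier compounds shown here showed only exchanges of a single group on a benzene ring, whereas here a ring with a hetero atom and no further group fits the same narrow band of numbers as compound 1 and compound 2. Compound 3 goes against this pattern, since a 42-fold lower number from compound 3 to compound 4 (1.62 log units; beyond the scatter), so among these four compounds the large rise is confined to the 3-aminophenyl group and is not a general result of leaving the nitro or bromo group behind.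

Nothing available here explains why these three different groups give such similar numbers. The compounds shown leave open whether pyridin-4-yl, with its ring nitrogen placed elsewhere, would match pyridin-3-yl, and whether 3-hydroxyphenyl or 3-carboxyphenyl would stay with compound 4 or rise as far as compound 3.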